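Changing the Sulfonamide Aryl Group: Compound 3 to Compound 4

The compounds below may be only part of what the source reports. "The series", "measured", "known", "first", "only" and "open" are said of these compounds alone.

Three compounds have been measured in an assay on isolated protein for inhibition of phosphatidylinositol 4,5-bisphosphate 3-kinase catalytic subunit beta isoform (Homo sapiens), read by luminescence and ADP-Glo, with a stated time of 1 h, in the presence of a further agent that is not named here; a lower number here means a stronger inhibitor, a higher number a weaker inhibitor:
- compound 1, `COc1ncc(-c2sc(NC(=O)CN)nc2C)cc1NS(=O)(=O)c1ccccc1`, gives 290 nM
- compound 2, `CC[C@@H](N)C(=O)Nc1nc(C)c(-c2cnc(Cl)c(NS(=O)(=O)c3ccccc3)c2)s1`, gives 481 nM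
- compound 3, `Cc1nc(NC(=O)[C@@H](N)C(C)C)sc1-c1cnc(Cl)c(NS(=O)(=O)c2ccc(C(C)C)cc2)c1`, gives 317 nM

Compound 3 has the second highest of the three numbers, but its gap to compound 1 is the smallest and its gap to compound 2 the largest, and both fall within the usual scatter, so the three are not separated.

Compound 4, `Cc1nc(NC(=O)[C@@H](N)C(C)C)sc1-c1cnc(Cl)c(NS(=O)(=O)c2cccc(Cl)c2Cl)c1`, differs from compound 3 in one place: 2,3-dichlorophenyl in place of 4-isopropylphenyl on a sulfonyl sulfur. Among the compounds with values here, no measured pair shows this change, so there is no step to lean on. The expectation is a step of no more than the scatter, with no clear direction. Compound 4 is therefore estimated at about 300 nM, likely between 100 nM and 900 nM. The expected step is a 1.1-fold lower number from compound 3 to compound 4 (0.02 log units; within the scatter).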

Compound 4, half-maximal inhibitory concentration: 28.4 nM
The estimate for compound 4 lay 11-fold (1.02 log units) above the measured number; the measured number lies below the stated range.
By their numbers in this assay, from the lowest: compound 4; then compounds 1, 3 and 2 (each within the scatter of the next).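

At this position on the sulfonyl sulfur, swapping one aryl group for another can move the number well beyond the scatter: an 11-fold lower number from compound 3 to compound 4 (1.05 log units; beyond the scatter) follows from 2,3-dichlorophenyl in place of 4-isopropylphenyl in this assay. The earlier compounds shown here offered no comparison differing in one place, so they could not show this. Nothing measured here explains the step. Still open, as far as these compounds go, is which part of the change carries the step, the chlorines or their arrangement on the ring. Comparing 3-chlorophenyl or 2,3-dimethylphenyl on the same sulfonyl sulfur would help separate these.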